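This account rests on a few compounds, and the source may have more. Where it says the series, first, only, none or still open, it means among the compounds named here.

Compound 1, `COc1ccc(Nc2ncc3cc(S(=O)(=O)c4ccc(C)cc4)c(=O)n(C)c3n2)cc1`, is the weaker of the two measured compounds: in a functional assay on DU-145 cells (Homo sapiens) for inhibition, read by trypan blue exclusion, with a stated time of 72 h (a lower number here means a stronger inhibitor, a higher number a weaker inhibitor), compound 1 gives 100000 nM. Compound 2, `Cc1ccc(S(=O)(=O)c2cc3cnc(Nc4cnc5[nH]ccc5c4)nc3n(C)c2=O)cc1`, is measured in this assay at 25000 nM, the lowest of the two numbers and therefore the stronger inhibitor here, by a 4.0-fold lower number from compound 1 to compound 2 (0.60 log units; beyond the scatter). That single measured step changes a group elsewhere in the molecule, not the ring that is altered next.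

Compound 3, `Cn1c(=O)c(S(=O)(=O)c2ccc(F)cc2)cc2cnc(Nc3cnc4[nH]ccc4c3)nc21`, differs from compound 2 in one place: fluoro in place of methyl on an aromatic carbon. No measured pair in this set swaps these two groups, so no shown step bears directly on this change; the one step known, from compound 1 to compound 2, concerns a different part of the molecule and gives no guidance on the size or direction to expect. With nothing to point either way, the expectation for this assay is a step no larger than the usual scatter, with the number for compound 3 expected close to that of compound 2. Compound 3 is therefore estimated at 25000 nM, with a range from 8000 nM to 70000 nM, which corresponds to an expected step of no change at the digits printed from compound 2 to compound 3 (within the scatter).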

Compound 3, half-maximal inhibitory concentration: 500 nM
Compound 3: middle estimate off by 50-fold (1.70 log units), on the high side; the measured number lies below the stated range.
By their numbers in this assay, from the lowest: compound 3; then compound 2; then compound 1.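

The change from (4-methylphenyl)sulfonyl to (4-fluorophenyl)sulfonyl gives a 50-fold lower number from compound 2 to compound 3 (1.70 log units; beyond the scatter) in this assay, so this position on the carbon-only aromatic ring, para to a large group, strongly affects the read-out. This single-atom exchange, with no ring, hydrogen-bond donor, hydrogen-bond acceptor or net charge entering or leaving, has a far larger effect than the replacement of a larger group elsewhere in the molecule, which gave a 4.0-fold lower number from compound 1 to compound 2 (0.60 log units; beyond the scatter). Nothing measured here explains why fluoro and methyl differ so sharply at this position, as no supporting evidence bears on the result.

As far as these compounds go, with only methyl and fluoro to compare at this position, it remains open whether the gain is specific to fluoro or comes from losing the methyl, a question that compounds carrying hydrogen, chloro or methoxy in the same place could help to settle. It is also unknown whether the same exchange would have a similar effect on the core of compound 1, where the group on the ring nitrogen's neighbouring amine differs.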